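Inverting one stereocentre of compound 1

A few compounds are considered here, and "the series" means these few. Any claim that something is new, unique, unknown or untested is made for them only; others in the source may bear on it.

In an ADME assay on liver for metabolic stability, with Liver microsome (Rattus norvegicus) as the target, read by LC-MS, using microsomes, with a stated time of 5 h (on this read-out higher numbers stand for fast clearance and lower numbers for slow clearance), compound 1 `C[C@]1(c2ccc(OC(F)(F)F)cc2)C[C@@](O)(c2ccccn2)CO1` gives 150 mL/min/kg and compound 2 `C[C@]1(O)C[C@@](c2ccc(OC(F)(F)F)cc2)([C@H](O)c2ccccn2)C1` gives 133 mL/min/kg on the same read-out. Among the measured compounds shown here, these two numbers lie within the usual scatter of each other, so compound 1 stands level with the only other measured compound. Compound 3 `C[C@]1(c2ccc(OC(F)(F)F)cc2)C[C@](O)(c2ccccn2)CO1` is the next to be read. The change from compound 1 is the two compounds have the same atoms and bonds and differ only in configuration as drawn: 1 of 2 stereo elements differ; a stereocentre at a saturated ring carbon is drawn R in compound 1 and S in compound 3. A stereocentre at a saturated ring carbon is drawn R in compound 1 and S in compound 3. For the measured compounds named here, no measured pair shows what such an inversion does in this assay and the data favour no direction. The expected change is a 1.1-fold lower number from compound 1 to compound 3 (0.05 log units; within the scatter) and it is estimated to stay within the scatter. In this assay compound 3 is expected at 135 mL/min/kg with an estimated range of 70 mL/min/kg to 230 mL/min/kg for the measurement.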

Compound 3, clearance: 167 mL/min/kg
Compound 3: middle estimate off by 1.2-fold (0.09 log units), on the low side; the measured number falls inside the stated range.
By their numbers in this assay, from the lowest: compounds 2, 1 and 3 (each within the scatter of the next).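

In this assay, inverting the stereocentre at the saturated ring carbon, drawn R in compound 1 and S in compound 3, gives a 1.1-fold higher number from compound 1 to compound 3 (0.05 log units; within the scatter). Among the compounds shown here, this is the first pair to read such an inversion, and at this position the configuration as drawn produces no step beyond the scatter. The comparison isolates that single centre, because nothing else separates the two structures: the fact that compounds 1 and 3 differ only in the configuration as drawn

The compounds shown leave open whether the inversion stays this small once an amine or a carboxylic acid is carried on the shared core. Which part of that core governs the clearance in this assay also remains unanswered: a single inversion exchanges no group.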